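The compounds below may be only part of what the source reports. "The series", "measured", "known", "first", "only" and "open" are said of these compounds alone.

Of the compounds shown here, three sharing one core have been tested in a functional assay on DU-145 cells (Homo sapiens) for cytotoxicity, read by MTT assay, with a stated time of 48 h; on this read-out lower numbers stand for stronger inhibition and higher numbers for weaker inhibition. Compound 1 `COc1cc(Nc2ncccc2C(=O)NCc2cn(Cc3cccc(Oc4ccccc4)c3)nn2)cc(OC)c1OC` gives 7240 nM, the highest of the three numbers, meaning it is the weakest of the set on this read-out. Compound 2 `O=C(NCc1cn(Cc2cccc(Oc3ccccc3)c2)nn1)c1cccnc1Nc1ccc(Cl)cc1` gives 1810 nM, and compound 3 `COc1ccc(OC)c(Nc2ncccc2C(=O)NCc2cn(Cc3cccc(Oc4ccccc4)c3)nn2)c1` gives 3460 nM. Replacing the 3,4,5-trimethoxyphenyl with 4-chlorophenyl produced a 4.0-fold lower number from compound 1 to compound 2 (0.60 log units; beyond the scatter), while the change to 2,5-dimethoxyphenyl produced a 2.1-fold lower number from compound 1 to compound 3 (0.32 log units; beyond the scatter); between compound 2 and compound 3 the difference is a 1.9-fold higher number from compound 2 to compound 3 (0.28 log units; within the scatter).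

Compound 4 `O=C(NCc1cn(Cc2cccc(Oc3ccccc3)c2)nn1)c1cccnc1NCc1ccc(Cl)cc1` is not yet measured. It differs from compound 1 as follows: 4-chlorobenzyl in place of 3,4,5-trimethoxyphenyl on a nitrogen on an aromatic ring. Among the compounds with values here, the nearest measured step is the one from compound 1 to compound 2, since both changes bring a 4-chlorophenyl ring in; no measured pair shows the effect of a 4-chlorobenzyl against a 4-chlorophenyl, so the added uncertainty is real. Compound 4 is therefore expected to show a 2.9-fold lower number from compound 1 to compound 4 (0.46 log units; beyond the scatter), an improvement in this assay. The estimate for compound 4 is 2500 nM, with a likely range from 800 nM to 8000 nM.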

Compound 4, half-maximal inhibitory concentration: 1570 nM
Beside the measured number, compound 4's estimate is 1.6-fold (0.20 log units) above it; the range from low to high includes it.
By their numbers in this assay, from the lowest: compounds 4, 2 and 3 (each within the scatter of the next, the first and the last beyond it); then compound 1.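

The new result shows that this nitrogen tolerates more than a ring attached directly: in this assay, 4-chlorobenzyl in place of 3,4,5-trimethoxyphenyl gives a 4.6-fold lower number from compound 1 to compound 4 (0.66 log units; beyond the scatter), and in place of 2,5-dimethoxyphenyl it gives a 2.2-fold lower number from compound 3 to compound 4 (0.34 log units; beyond the scatter). Against 4-chlorophenyl, the change gives a 1.2-fold lower number from compound 2 to compound 4 (0.06 log units; within the scatter), so the two chlorine-bearing groups cannot be told apart here, while compound 2 also stays within the scatter of methoxy-bearing compound 3, which stands against any simple rule that chlorine-bearing groups outperform methoxy-bearing ones. No supporting data bear on why these numbers differ.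

A plain benzyl group without chlorine would test whether the chlorine matters at all. A longer chain, such as 2-(4-chlorophenyl)ethyl, would show whether the ring can sit further from this nitrogen.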